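What a chloro group might do to compound 3

A few compounds are considered here, and "the series" means these few. Any claim that something is new, unique, unknown or untested is made for them only; others in the source may bear on it.

Compound 1 (`c1ccc(-c2ccc(-c3ccc(-c4nc5ccccc5[nH]4)cc3)cc2)cc1`) reads 100000 nM in a functional assay on HOP-62 cells (Homo sapiens) for inhibition, read by sulforhodamine B assay (on this read-out higher numbers stand for weaker inhibition of growth and lower numbers for stronger inhibition of growth), and compound 2 (`CN(C)c1ccc(-c2ccc(-c3ccc(-c4nc5ccccc5[nH]4)cc3)cc2)cc1`) reads 100000 nM in this assay as well. Compound 3 (`Oc1cccc2[nH]c(-c3ccc(-c4ccc(-c5ccccc5)cc4)cc3)nc12`) reads 9040 nM there, the lowest of the three numbers and so the strongest inhibition of growth among them.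

Compound 4 (`Oc1cccc2[nH]c(-c3ccc(-c4ccc(-c5cccc(Cl)c5)cc4)cc3)nc12`) has not been measured yet. It differs from compound 3 by a single change, chloro in place of hydrogen on an aromatic carbon, which turns a phenyl into 3-chlorophenyl (chloro in place of hydrogen on an aromatic carbon).

For the measured compounds named here, no measured step shows this change directly, so the guidance is indirect. Putting dimethylamino in place of hydrogen on an aromatic carbon gave no change at the digits printed from compound 1 to compound 2 (within the scatter) and shows that an added group need not move the number. Putting hydroxy in place of hydrogen on an aromatic carbon gave an 11-fold lower number from compound 1 to compound 3 (1.04 log units; beyond the scatter) as a large step, but compound 4 keeps that hydroxy, so this gain is already included in the starting value.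

The expected result is therefore a small change, estimated as a 1.3-fold lower number from compound 3 to compound 4 (0.11 log units; within the scatter) in this assay for now. For compound 4 the estimated value is 7000 nM with an expected range from 2500 nM to 20000 nM as its likely reading.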

Compound 4, concentration for 50% growth inhibition: 2260 nM
Estimate against measurement, compound 4: 3.1-fold (0.49 log units) above; measured number outside the range, below it.
By their numbers in this assay, from the lowest: compound 4; then compound 3; then compounds 1 and 2 (each within the scatter of the next).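

In this assay, chloro in place of hydrogen on the phenyl of compound 3 gave a 4.0-fold lower number from compound 3 to compound 4 (0.60 log units; beyond the scatter), so a single added atom on this ring can move the number by more than the usual scatter, and towards stronger inhibition of growth. For the compounds shown here, the only earlier change on this same phenyl, the dimethylamino group of compound 2, gave no change at the digits printed from compound 1 to compound 2 (within the scatter), but that step was taken on a compound without the hydroxy, so the two steps differ in their starting point as well as in the added group. Nothing measured here gives a reason for the chloro step.

The compounds shown leave open whether chloro itself matters or whether other groups on this ring, such as fluoro, methoxy, an amine or a carboxylic acid, would do the same, and whether 2-chlorophenyl or 4-chlorophenyl would match 3-chlorophenyl. They also leave open whether chloro would lower the number on the core of compound 1, which has no hydroxy, or whether its step depends on the hydroxy being present.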